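The compounds below may be only part of what the source reports. "The series", "measured", "known", "first", "only" and "open" are said of these compounds alone.

Compound 2 `NCCCCc1c[nH]c2c(F)cccc12` gives 21 nM in an assay on isolated protein for inhibition of Myeloperoxidase (Homo sapiens), read by ELISA, with a stated time of 5 min (a higher number here means a weaker inhibitor, a lower number a stronger inhibitor), and stands second highest of the three numbers measured. Compound 1 `NCCCc1c[nH]c2c(F)cccc12` gives 26 nM in this assay, and compound 3 `NCCSCCc1c[nH]c2ccc(F)cc12` gives 8 nM. Within the data shown here, the only single-site step among the measured compounds is a 1.2-fold lower number from compound 1 to compound 2 (0.09 log units; within the scatter), which lengthens the chain while keeping the amino group. Compound 4 `NC(=O)CCc1c[nH]c2c(F)cccc12` differs from compound 2 by carbamoyl in place of 2-aminoethyl on a saturated chain carbon, two bonds along the chain from an aromatic carbon. That exchange of the amino end for a carbamoyl group is not covered by the step from compound 1 to compound 2, and compound 3 differs in several places at once. Among the measured compounds shown here, with no measured step bearing on it, the step is estimated as a 7.1-fold higher number from compound 2 to compound 4 (0.85 log units; beyond the scatter), with wide uncertainty. Compound 4 is expected to give about 150 nM, in the range 25 nM to 1500 nM.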

Compound 4, half-maximal inhibitory concentration: 64 nM
The estimate for compound 4 lay 2.3-fold (0.37 log units) above the measured number; low and high end bracket the measured number.
By their numbers in this assay, from the lowest: compound 3; then compounds 2 and 1 (each within the scatter of the next); then compound 4.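

In this assay the exchange of the amino end for carbamoyl gives a 3.0-fold higher number from compound 2 to compound 4 (0.48 log units; beyond the scatter) and likewise a 2.5-fold higher number from compound 1 to compound 4 (0.39 log units; beyond the scatter) so this change, unlike the lengthening of the chain, moves the number beyond the scatter. Both steps are modest, and compound 4 still gives 64 nM so among these compounds an amino end is not required for inhibition.

The compounds leave open whether a carboxylic acid, a hydroxyl group or a longer amide chain at this place would give a number closer to that of compound 4 or of compound 2. Nothing available here accounts for the size of these steps.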